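The source may report more compounds than this note shows. Statements on the series, on what has been measured and on what is new or still open speak of the compounds shown alone.

The three compounds with numbers in an ADME assay on the whole organism (Macaca fascicularis) for metabolic stability, read by LC-MS, using cassette dosing, at a dose of 1 mg/kg by the oral route (a higher number here means that the compound lasts longer, a lower number that the compound disappears faster), are compound 1 `CCCCN(c1nc2c(C(=O)NC)cccc2o1)[C@H](C)c1ccc(-c2ccccc2-c2nnn[nH]2)cc1`, compound 2 `Cc1ccc(-c2nc(=O)o[nH]2)c(-c2ccc([C@@H](C)N(CC3CC3)c3nc4c(C(=O)O)cccc4o3)cc2)c1` and compound 3 `CCCCN(c1nc2c(C(=O)O)cccc2o1)[C@H](C)c1ccc(-c2cc(Cl)ccc2-c2nc(=O)o[nH]2)cc1`. In this assay compound 1 gives 1.3 h. Going by the values given here, compound 3 gives 2 h, a number that lies within the scatter of the one for compound 1. Compound 2 gives 2.8 h, a higher number than that of compound 1, and this gap lies beyond the scatter. Compound 1 thus holds the lowest of the three numbers, with compound 3 nearest to it and compound 2 furthest. Compounds 2 and 3 differ from compound 1 in more than one place, so their numbers say nothing about any single change.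

Compound 4 `CCCCN(c1nc2c(C(=O)N(C)C)cccc2o1)[C@H](C)c1ccc(-c2ccccc2-c2nnn[nH]2)cc1` is not yet measured. It differs from compound 1 in one place: methyl in place of hydrogen on an amide-type nitrogen. Among the compounds with values here, no measured pair carries this change, so nothing shows what such a step does to the half-life. The expectation is a step from compound 1 to compound 4 of no change at the digits printed from compound 1 to compound 4 (within the scatter), that is, no change beyond the scatter in either direction. Compound 4 is accordingly expected to give about 1.3 h in this assay, with a range from 0.6 h to 2.8 h.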

Compound 4, half-life: 3.2 h
Compound 4: middle estimate off by 2.5-fold (0.39 log units), on the low side; the measured number lies above the stated range.
By their numbers in this assay, from the lowest: compounds 1, 3, 2 and 4 (each within the scatter of the next, the first and the last beyond it).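

In this assay, going by these compounds alone, methyl in place of hydrogen on the amide-type nitrogen gives the first step that can be read at a single place: a 2.5-fold higher number from compound 1 to compound 4 (0.39 log units; beyond the scatter). This shows that the half-life can respond beyond the scatter to the change from methylcarbamoyl to dimethylcarbamoyl, a reading that compounds 2 and 3 could not give, as each differs from compound 1 in more than one place. No measurement shown here speaks to the reason for this step, whether on the route of loss or on any property of the two compounds.

Still open, going by these compounds, is whether a longer chain on the same nitrogen, such as ethyl in place of the added methyl, carries the step further, and how the unsubstituted carbamoyl group, with two hydrogens on that nitrogen, would stand against compound 1. On these data alone, this is also a single pair, so it remains open whether the same methyl gives a step of this size when other groups stand elsewhere on the core.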